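Replacing the 2,6-dichlorophenyl group of compound 2

The source may hold more compounds than are shown below. What is called first, only, known or untested is meant among the compounds shown, and "the series" means these compounds.

Measured in a functional assay on NCI-H460 cells (Homo sapiens) for inhibition, read by MTT assay, with a stated time of 48 h; a higher number here means a weaker inhibitor, a lower number a stronger inhibitor:
Compound 1 `O=C(CC(c1ccc(F)cc1)C(C(=O)Nc1ccccn1)C(=O)Nc1ccccn1)c1ccccc1`: "not active" (no number reported)
Compound 2 `O=C(CC(c1c(Cl)cccc1Cl)C(C(=O)Nc1ccccn1)C(=O)Nc1ccccn1)c1ccccc1`: 27400 nM

For the measured compounds named here, compound 2 holds the only number so far, so there is no second number to rank it against. Compound 1 gave no number at all. Compound 3 `COc1ccc(C(CC(=O)c2ccccc2)C(C(=O)Nc2ccccn2)C(=O)Nc2ccccn2)cc1` keeps the shared core of compound 2 and alters one group: 4-methoxyphenyl in place of 2,6-dichlorophenyl on a saturated chain carbon bound to two saturated chain carbons. Going by the values given here, no measured step exists to show how much such a swap matters. With compound 2 at 27400 nM and compound 1 reported as "not active" (no number reported), compound 3 is expected to remain a weak inhibitor in this assay, and a result without a number is possible. No change beyond the scatter is expected, and the estimated step runs a 1.1-fold higher number from compound 2 to compound 3 (0.04 log units; within the scatter). For compound 3 the estimate is 30000 nM, with an expected range of 10000 nM to 80000 nM.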

Compound 3, half-maximal inhibitory concentration: "not active" (no number reported)
Nothing numeric was reported for compound 3; no gap can be computed for the estimate.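

For the compounds shown here, compound 3, like compound 1, gave no number, and no step from compound 2 to compound 3 can be read. Nothing measured here bears on this result. The compounds shown leave open how much the group on the saturated chain carbon affects inhibition.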